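From phenyl to 4-chlorophenyl on compound 3

This account rests on a few compounds, and the source may have more. Where it says the series, first, only, none or still open, it means among the compounds named here.

Of the compounds shown here, three have numbers so far in a functional assay on MDA-MB-435 cells (Homo sapiens) for inhibition, with a stated time of 48 h (a lower number here means a stronger inhibitor of growth, a higher number a weaker inhibitor of growth), and all of them are only moderate inhibitors. Compound 1 (`COc1ccccc1/C=C/C(=O)c1c(O)cc2occc2c1OC`) gives 5690 nM there, compound 2 (`COc1c(C(=O)/C=C/c2ccc(Cl)cc2)c(O)c(Br)c2occc12`) gives 3050 nM and compound 3 (`C=CCc1c(O)c(C(=O)/C=C/c2ccccc2)c(OC)c2ccoc12`) gives 2780 nM as its read-out. Compound 3 and compound 2 lie within the scatter of each other and cannot be ranked. Compound 3 does stand below compound 1, by a gap beyond the scatter.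

Compound 4 (`C=CCc1c(O)c(C(=O)/C=C/c2ccc(Cl)cc2)c(OC)c2ccoc12`) has not yet been measured. It differs from compound 3 in one place: chloro in place of hydrogen on an aromatic carbon, para to a large group, which turns phenyl to 4-chlorophenyl (chloro in place of hydrogen on an aromatic carbon) on an otherwise unchanged structure.

Among the measured compounds shown here, no pair of measured compounds differs in this place alone, so the data offer no direct guide. Compound 2 also carries the 4-chlorophenyl and gives 3050 nM in the same test, within the scatter of compound 3, so a large shift in this assay is not expected. The expected step of a 1.2-fold lower number from compound 3 to compound 4 (0.08 log units; within the scatter) is estimated to be slightly toward a lower number and probably no larger than the scatter. For compound 4 the expected value is 2300 nM with a range from 1100 nM to 4600 nM as estimated here.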

Compound 4, concentration for 50% growth inhibition: 2060 nM
Estimate against measurement, compound 4: 1.1-fold (0.05 log units) above, within the range that was stated.
By their numbers in this assay, from the lowest: compounds 4, 3, 2 and 1 (each within the scatter of the next, the first and the last beyond it).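

In this assay, among the compounds shown here, this is the first direct reading of chloro in place of hydrogen on an aromatic carbon, para to a large group, with everything else on the structure held constant. It gives a 1.3-fold lower number from compound 3 to compound 4 (0.13 log units; within the scatter), so compound 3 and compound 4 cannot be ranked, and phenyl to 4-chlorophenyl shows no effect on this core that can be told from the scatter. The result also creates a second one-place comparison, allyl in place of bromo on an aromatic carbon with the 4-chlorophenyl kept, which gives a 1.5-fold lower number from compound 2 to compound 4 (0.17 log units; within the scatter), so compound 2 and compound 4 cannot be ranked either, and no other kind of measurement is available to bear on these two results.

Hydrogen and chloro are the only groups compared directly at this place on the ring, so it remains open whether a nitrile, an amine or a carboxylic acid there would give a step beyond the scatter. From the compounds shown here alone, it also remains open what a longer chain in place of the allyl would give with the 4-chlorophenyl kept.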